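A few compounds are considered here, and "the series" means these few. Any claim that something is new, unique, unknown or untested is made for them only; others in the source may bear on it.

Compounds measured in an assay on cell membranes for displacement of a labelled ligand from corticotropin-releasing factor receptor 1 (Rattus norvegicus); on this read-out lower numbers stand for stronger inhibition and higher numbers for weaker inhibition:
compound 1, `CCOCC(COCC)Nc1nc(C)nc2c(-c3ccc(OC)cc3C)c(C)nn12`: 19.3 nM
compound 2, `CCCN(CCC#N)c1nc(C)nc2c(-c3ccc(OC)cc3C)c(C)nn12`: 2.16 nM

Compound 2 gives the lowest number of the two, the next being compound 1 with a step of an 8.9-fold lower number from compound 1 to compound 2 (0.95 log units; beyond the scatter). Compound 3, `CCCCN(CC)c1nc(C)nc2c(-c3ccc(OC)cc3C)c(C)nn12`, shares the core of compound 2 and differs from it in one place: butyl(ethyl)amino in place of (2-cyanoethyl)(propyl)amino on an aromatic carbon. Only one measured step is shown, and it concerns the same position but a different pair of groups: the exchange giving an 8.9-fold lower number from compound 1 to compound 2 (0.95 log units; beyond the scatter). It shows that this position tolerates a change of amino substituent with a clear gain, but nothing shown tests removing a nitrile or lengthening the chain, so no direction can be read from it. The expectation for compound 3 in this assay is therefore a step of about a 1.2-fold higher number from compound 2 to compound 3 (0.06 log units; within the scatter), within the scatter. Compound 3 is estimated at 2.5 nM, with a range from 0.8 nM to 8 nM.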

Compound 3, half-maximal inhibitory concentration: 2.3 nM
Estimate against measurement, compound 3: 1.1-fold (0.04 log units) above; the measured number falls inside the stated range.
By their numbers in this assay, from the lowest: compounds 2 and 3 (each within the scatter of the next); then compound 1.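

In this assay, the step of a 1.1-fold higher number from compound 2 to compound 3 (0.03 log units; within the scatter) shows that butyl(ethyl)amino and (2-cyanoethyl)(propyl)amino cannot be told apart at this aromatic carbon, so a low number here does not require the nitrile. The step of an 8.4-fold lower number from compound 1 to compound 3 (0.92 log units; beyond the scatter) confirms that the gain over (2-ethoxy-1-(ethoxymethyl)ethyl)amino is not tied to that group, since a substituent made only of carbon chains on the nitrogen also achieves it. No measurement is available that explains why these substituents behave this way.

The compounds shown do not separate the effect of having two chains on the nitrogen from that of losing the ethoxy groups. As far as these compounds go, it also remains open how this position would respond to a longer pair of chains, as in dibutylamino, or to a carboxylic acid at the end of a chain.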